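Trading the aminophenyl of compound 1 for a difluorophenyl

This account rests on a few compounds, and the source may have more. Where it says the series, first, only, none or still open, it means among the compounds named here.

Of the compounds shown here, three of a shared core have been tested in a functional assay on TK-10 cells (Homo sapiens) for cytotoxicity, read by sulforhodamine B assay, with a stated time of 48 h, tested at 100 uM; on this read-out higher numbers stand for a weaker effect at the one concentration tested and lower numbers for a stronger effect. Compound 1 `COc1cc(-c2cc(/C=C/C(=O)c3ccc(N)cc3)[nH]n2)cc(OC)c1OC` gives -81% in this assay, the highest of the three numbers; compound 2 `COc1ccc(-c2cc(/C=C/C(=O)c3ccc(OC)c(OC)c3)[nH]n2)cc1` gives -98%, and compound 3 `COc1cc(C(=O)/C=C/c2cc(-c3cc(OC)c(OC)c(OC)c3)n[nH]2)cc(OC)c1OC` gives -99%. Both of those gaps to compound 1 lie beyond the usual scatter, so compound 1 shows the weakest effect of the three at the single concentration tested, while compound 2 and compound 3 sit within the scatter of each other.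

Compound 4 `COc1cc(-c2cc(/C=C/C(=O)c3ccc(F)c(F)c3)[nH]n2)cc(OC)c1OC` has not been measured. It differs from compound 1 in one place: 3,4-difluorophenyl in place of 4-aminophenyl on a carbonyl carbon

Among the compounds with values here, no measured pair shows this change, so its effect on the read-out can only be estimated. Compound 2 and compound 3 show that the shared core can reach lower numbers than compound 1 does, and compound 4 is expected to move toward them: the estimated step of a number 10 percentage points lower from compound 1 to compound 4 (within the scatter) is a modest move to a lower number, though it may not clear the scatter. For compound 4 in this assay the expected value is -91%, with a range from -100% to -74%.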

Compound 4, a percentage reported as activity, at one concentration (the size of the read-out at that concentration, not a potency): -37%
The estimate for compound 4 lay 54 percentage points below the measured number; measured number above the stated range.
By their numbers in this assay, from the lowest: compounds 3 and 2 (each within the scatter of the next); then compound 1; then compound 4.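

In this assay, 3,4-difluorophenyl in place of 4-aminophenyl on a carbonyl carbon gives a number 44 percentage points higher from compound 1 to compound 4 (beyond the scatter), so the effect at the one concentration tested weakens markedly. The earlier compounds shown here differ from one another in more than one place and could not isolate this position; this pair shows that the group on the carbonyl carbon can, with the rest of compound 1 unchanged, decide much of the read-out. The data offer no measured explanation for the size of this step.

The single change both removes the amine and brings in the fluorines, and the compounds shown do not separate these two parts. On these data alone, whether a plain phenyl, a monofluorophenyl or a hydroxyphenyl at this place would stay close to compound 1 or to compound 4 remains open.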